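One aryl exchange from compound 2 to compound 3

A few compounds are considered here, and "the series" means these few. Any claim that something is new, unique, unknown or untested is made for them only; others in the source may bear on it.

Compound 1 `Nc1nc(NCCNc2ncc(-c3ncc[nH]3)c(-c3cc(F)ccc3Cl)n2)ccc1[N+](=O)[O-]` gives > 0.5 h as a limit
Compound 2 `Cc1ccc(-c2nc(NCCNc3ccc([N+](=O)[O-])c(N)n3)ncc2-c2ncc[nH]2)c(Br)c1` gives > 0.5 h as a limit

Both readings come from an ADME assay on microsomes from liver (Canis lupus familiaris) for metabolic stability (on this read-out lower numbers stand for a shorter-lived compound and higher numbers for a longer-lived compound), and are limits of the assay, not numbers. Compound 2 stands only at its limit of > 0.5 h and has no number of its own. The record so far is thus the limit of > 0.5 h in this assay, at which 2 of the 2 values shown sit, and no more.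

The change to compound 3 `COc1cc(Cl)ccc1-c1nc(NCCNc2ccc([N+](=O)[O-])c(N)n2)ncc1-c1ncc[nH]1` puts 4-chloro-2-methoxyphenyl in place of 2-bromo-4-methylphenyl on an aromatic carbon next to the ring nitrogen (4-chloro-2-methoxyphenyl in place of 2-bromo-4-methylphenyl on an aromatic carbon). Among the measured compounds shown here, the one measured step, also an exchange on an aromatic carbon, is a step that the two limits leave unreadable from compound 1 to compound 2 and gives no size to carry over, so no step beyond the scatter is expected in this assay and no direction can be named. The step expected is a step that the limit leaves unreadable from compound 2 to compound 3 and rests on very little. Compound 3 is estimated at 0.8 h with 0.45 h and 2 h as the ends of its expected range.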

Compound 3, half-life: > 0.5 h
Compound 3 was reported as a limit; the forecaster's own chance of this, stated with the estimate: 70%; the middle value does not contradict the limit.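

In this assay compound 3 gives > 0.5 h as a limit of the assay, not a number. Among the compounds shown here, no step to compound 3 from compound 1 or compound 2 can be read. The compounds shown leave open how long each of the three actually lasts in this assay and whether their aryl groups separate them at all.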